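Aryl swap on a ring nitrogen of compound 3

The compounds below may be only part of what the source reports. "The series", "measured", "known", "first", "only" and "open" are said of these compounds alone.

Compound 3 `COc1cc2c(Oc3ccc(NC(=O)c4nnn(-c5ccc(F)cc5)c4C(F)(F)F)cc3F)ccnc2cc1OCCCN1CCC(C)CC1` was tested in a functional assay on NCI-H460 cells (Homo sapiens) for cytotoxicity, read by MTT assay, with a stated time of 72 h (on this read-out higher numbers stand for weaker inhibition and lower numbers for stronger inhibition), where compound 3 gives 190 nM. Compound 2 `COc1cc2c(Oc3ccc(NC(=O)c4nnn(-c5ccc(F)cc5)c4C(F)(F)F)cc3F)ccnc2cc1OCCCN1CCCCC1` gives 190 nM in this assay, and the step of no change at the digits printed from compound 2 to compound 3 (within the scatter) from compound 2 to compound 3 is within the scatter; the two numbers stand level as the lowest of the three measured. Compound 1 `COc1cc2c(Oc3ccc(NC(=O)c4nnn(-c5ccccc5C(F)(F)F)c4C(F)(F)F)cc3F)ccnc2cc1OCCCN1CCCC1` gives 270 nM, which differs from compound 3 by only a small margin that also lies within the scatter.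

Compound 4 `COc1cc2c(Oc3ccc(NC(=O)c4nnn(-c5ccccc5C(F)(F)F)c4C(F)(F)F)cc3F)ccnc2cc1OCCCN1CCC(C)CC1` has not yet been measured. It differs from compound 3 by 2-(trifluoromethyl)phenyl in place of 4-fluorophenyl on an aromatic nitrogen. Within the data shown here, no single measured step isolates this exchange: compound 1 carries the 2-(trifluoromethyl)phenyl group but also differs from compound 2 in a second place, so the pair of compounds 1 and 2 can only show that their values sit close together. On that basis the aryl exchange is expected to move the number in this assay little, if at all, in either direction beyond the scatter, and the estimated step of a 1.2-fold higher number from compound 3 to compound 4 (0.08 log units; within the scatter) from compound 3 to compound 4 is therefore small. Compound 4 is expected to give about 230 nM, with a range from 120 nM to 450 nM.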

Compound 4, half-maximal inhibitory concentration: 250 nM
The estimate for compound 4 lay 1.1-fold (0.04 log units) below the measured number; measured number inside the range.
By their numbers in this assay, from the lowest: compounds 2, 3, 4 and 1 (each within the scatter of the next).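

The exchange of 4-fluorophenyl for 2-(trifluoromethyl)phenyl on the aromatic nitrogen can now be read on its own in this assay: the step of a 1.3-fold higher number from compound 3 to compound 4 (0.12 log units; within the scatter) lies within the scatter, so this place accepts a group of 10 heavy atoms in place of one of 7 with no readable difference, even though the neighbouring ring atom bears a trifluoromethyl group. The step of a 1.1-fold lower number from compound 1 to compound 4 (0.03 log units; within the scatter) isolates 4-methylpiperidin-1-yl in place of pyrrolidin-1-yl at the end of the chain with the 2-(trifluoromethyl)phenyl group held constant, and it too lies within the scatter, so neither exchange separates these compounds on this read-out. Nothing available here gives a reason for either result, and no other data bear on these two exchanges.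

As far as these compounds go, since the two aryl groups differ in both the substituent and its place on the ring, it remains open whether 2-fluorophenyl or 4-(trifluoromethyl)phenyl would give a similar number. It also remains open whether a morpholine or a dimethylamino group at the end of the chain, or an unsubstituted phenyl on the aromatic nitrogen, would stay within the scatter of these compounds.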